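The source may hold more compounds than are shown below. What is called first, only, known or untested is meant among the compounds shown, and "the series" means these compounds.

Measured so far in an assay on isolated protein for inhibition of GMP reductase 2 (Homo sapiens), read by spectrophotometry; on this read-out higher numbers stand for weaker inhibition and lower numbers for stronger inhibition:

- compound 2, `COc1ccc(-c2nc3cc(NC(=O)[C@H](C)Oc4cccc(Cl)c4Cl)ccc3o2)cc1`: compound 2 gives > 5000 nM, a limit of this assay.
- compound 1, `C[C@H](Oc1cccc(F)c1F)C(=O)Nc1ccc2oc(-c3ccc(F)cc3)nc2c1`: compound 1 gives > 5000 nM, a limit of this assay.

For the measured compounds named here, compound 2 stands at the limit rather than at a number, and the only other value in this assay is a limit too, so that both values sit at the limit of > 5000 nM in this assay, at which 2 of the 2 values shown sit. Going by the values given here, no step between two measured numbers exists, and nothing separates compound 2 from compound 1 on the numbers.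

Compound 3, `C[C@H](Oc1cccc(Cl)c1Cl)C(=O)Nc1ccc2oc(-c3ccc(F)cc3)nc2c1`, has not been measured. It differs from compound 2 in one place: fluoro in place of methoxy on an aromatic carbon. The rest of the molecule, the dichloro-substituted aryl ether and the amide on the shared core, is kept.

Expectation for this step: no step beyond the scatter is expected, and the estimated step that the limit leaves unreadable from compound 2 to compound 3 is set near zero because compound 2 shows only > 5000 nM and compound 1, which carries the same fluorophenyl group, also shows only > 5000 nM. Compound 3 is therefore expected to remain at or beyond the limit, with an estimate of 9000 nM (range 3000 nM to 40000 nM), and a reported limit rather than a number is the most likely outcome.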

Compound 3, inhibition constant: > 5000 nM
Compound 3 ended at the assay's limit (the forecaster's own chance of this, stated with the estimate: 75%); the middle value is on the limit's open side.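

No step to compound 3 can be read from compound 2 or compound 1, because all three compounds stand at a limit and not at a number: the limit of > 5000 nM in this assay, at which 3 of the 3 values shown sit.

The compounds shown leave open how far each lies past that limit, and whether any other substitution on the shared core would give a readable value in this assay at all.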